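Phenethyloxy in place of tert-butoxy at the uridine oxime

The source may report more compounds than this note shows. Statements on the series, on what has been measured and on what is new or still open speak of the compounds shown alone.

Measured compounds:
compound 1, `O=c1[nH]/c(=N\OCc2ccccc2)ccn1[C@@H]1O[C@H](COP(=O)(O)OP(=O)(O)OP(=O)(O)OP(=O)(O)O[C@H]2O[C@H](CO)[C@@H](O)[C@H](F)[C@H]2O)[C@@H](O)[C@H]1O`, 2640 nM
compound 2, `CO/N=c1/ccn([C@@H]2O[C@H](COP(=O)(O)OP(=O)(O)OP(=O)(O)OP(=O)(O)O[C@H]3O[C@H](CO)[C@@H](O)[C@H](F)[C@H]3O)[C@@H](O)[C@H]2O)c(=O)[nH]1`, 500 nM
compound 3, `CC(C)(C)O/N=c1/ccn([C@@H]2O[C@H](COP(=O)(O)OP(=O)(O)OP(=O)(O)O)[C@@H](O)[C@H]2O)c(=O)[nH]1`, 1500 nM

All three were tested in an in vitro functional assay on 1321-N1 cells for agonist activity at P2Y purinoceptor 2 (Homo sapiens), read by scintillation proximity assay and inositol phosphate accumulation, with a stated time of 30 min; a higher number here means that more compound is needed for the effect, a lower number that less compound is needed. Compound 3 stands second highest of the three numbers: its nearest neighbour is compound 1, a gap within the usual scatter, and its furthest is compound 2, a gap beyond the scatter.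

Compound 4, `O=c1[nH]/c(=N\OCCc2ccccc2)ccn1[C@@H]1O[C@H](COP(=O)(O)OP(=O)(O)OP(=O)(O)O)[C@@H](O)[C@H]1O`, has not yet been measured. It differs from compound 3 by phenethyl in place of tert-butyl on an oxygen. For the measured compounds named here, only one measured step bears on this change: a 5.3-fold lower number from compound 1 to compound 2 (0.72 log units; beyond the scatter), where taking the phenyl away lowered the number. Going from compound 3 to compound 4 adds a phenyl ring and lengthens the chain, the opposite direction, so the number is expected to rise, though the tetraphosphate pair of compounds 1 and 2 differs in its phosphate chain from compounds 3 and 4, which weakens the parallel. Compound 4 is therefore estimated at 3500 nM, with a range from 1200 nM to 10000 nM, a step of a 2.3-fold higher number from compound 3 to compound 4 (0.37 log units; beyond the scatter) expected relative to compound 3.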

Compound 4, half-maximal effective concentration: 1200 nM
The estimate for compound 4 lay 2.9-fold (0.46 log units) above the measured number; the range from low to high includes it.
By their numbers in this assay, from the lowest: compound 2; then compounds 4, 3 and 1 (each within the scatter of the next, the first and the last beyond it).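

In this assay, phenethyl in place of tert-butyl on the oxygen gives a 1.3-fold lower number from compound 3 to compound 4 (0.10 log units; within the scatter), so on this triphosphate the exchange brings in a six-membered aromatic ring and a larger group without a step beyond the scatter. The earlier step, a 5.3-fold lower number from compound 1 to compound 2 (0.72 log units; beyond the scatter), involved the loss of a phenyl and lay beyond the scatter, but it belonged to the fluorinated sugar tetraphosphate pair, and its size does not recur in this pair. Nothing shown offers an explanation for this difference between the two steps.

From the compounds shown here alone, it remains open whether a longer chain, such as phenylpropyl, or an amine or carboxylic acid on the phenyl ring would leave the number as little changed. Also open, going by these compounds, is how phenethyl would behave on the tetraphosphate of compound 1.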